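Hydroxyphenyl placement in a three-arm series

The source may hold more compounds than are shown below. What is called first, only, known or untested is meant among the compounds shown, and "the series" means these compounds.

Compound 1 `Oc1ccc(-c2cc(-c3ccc(O)cc3)nc(-c3ccc(O)cc3)c2)cc1` stands at the highest number of the two measured: in an ADME assay on HEK293 cells (Homo sapiens) for cytotoxicity, read by CCK-8 assay, with a stated time of 4 days (a lower number here means a stronger inhibitor, a higher number a weaker inhibitor), compound 1 gives 790 nM. Compound 2 `Oc1cccc(-c2cc(-c3ccccc3O)nc(-c3ccccc3O)c2)c1` gives 80 nM in this assay, and the two values lie beyond the scatter. Compound 3 `Oc1ccc(-c2cc(-c3ccccc3O)cc(-c3ccc(O)cc3)n2)cc1` differs from compound 1 by 2-hydroxyphenyl in place of 4-hydroxyphenyl on an aromatic carbon. For compound 3 a moderate fall in this assay is expected, a 2.0-fold lower number from compound 1 to compound 3 (0.30 log units; within the scatter), because compound 2, in which all three hydroxyphenyl groups are 2-hydroxyphenyl or 3-hydroxyphenyl, gives 80 nM. Compound 3 is estimated at 400 nM in this assay, within 150 nM to 1000 nM.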

Compound 3, half-maximal inhibitory concentration: 780 nM
Estimate against measurement, compound 3: 2.0-fold (0.29 log units) below; the range from low to high includes it.
By their numbers in this assay, from the lowest: compound 2; then compounds 3 and 1 (each within the scatter of the next).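

In this assay, 2-hydroxyphenyl in place of 4-hydroxyphenyl on the aromatic carbon opposite the ring nitrogen gives a 1.0-fold lower number from compound 1 to compound 3 (0.01 log units; within the scatter), so the two placements cannot be told apart at this position. Within the data shown here, this is the first comparison confined to one place; compound 2 differs from compound 3 in more than one place, so its value cannot be assigned to any single arm. No available data bear on why the two placements read alike. Still open, on these data alone, are the effect of the same change on the other two arms, and whether an amine or a carboxylic acid in place of the hydroxyl at this position would separate from compound 1.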